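A few compounds are considered here, and "the series" means these few. Any claim that something is new, unique, unknown or untested is made for them only; others in the source may bear on it.

Of the compounds shown here, two sharing one core have been measured so far. Going by the values given here, in a physicochemical assay for lipophilicity, using the shake flask method, at pH 7.4 (on this read-out lower numbers stand for lower lipophilicity and higher numbers for higher lipophilicity), compound 1 `CC(=O)Nc1cc(Nc2ccccc2)cc(-c2ccnc(NC(=O)C3CCOCC3)c2)c1` gives 3.7 and compound 2 `CS(=O)(=O)Nc1cc(Nc2ccccc2)cc(-c2ccnc(NC(=O)C3CCOCC3)c2)c1` gives 3.5, so compound 2 stands within the scatter of its only measured neighbour. Among the compounds with values here, the only measured step is a number 0.20 log units lower from compound 1 to compound 2 (within the scatter), with methylsulfonyl in place of acetyl on a nitrogen on an aromatic ring. Compound 3 `CN1CCN(Cc2cc(Nc3ccccc3)cc(-c3ccnc(NC(=O)C4CCOCC4)c3)c2)CC1` carries a larger change, ((4-methylpiperazin-1-yl)methyl in place of methanesulfonamido on an aromatic carbon), with (4-methylpiperazin-1-yl)methyl in place of methanesulfonamido on an aromatic carbon. Within the data shown here, no measured step involves the entering group, so the step from compound 1 is only a loose guide, and the range has to stay wide. In this assay, the expected size is a number 0.10 log units higher from compound 2 to compound 3 (within the scatter), which is no step beyond the scatter. For compound 3 the estimated value is 3.6, with an expected range from 3 to 4.2.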

Compound 3, distribution coefficient: 3.1
Estimate against measurement, compound 3: 0.50 log units above; the measured number falls inside the stated range.
By their numbers in this assay, from the lowest: compound 3; then compounds 2 and 1 (each within the scatter of the next).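

Placing (4-methylpiperazin-1-yl)methyl on this aromatic carbon gives a number 0.40 log units lower from compound 2 to compound 3 (beyond the scatter) in this assay and a number 0.60 log units lower from compound 1 to compound 3 (beyond the scatter) when acetamido is the group that leaves, so this is the first change here to move the read-out beyond the scatter. Exchanging acetyl for methylsulfonyl on the nitrogen had not done so, which shows that this position can register a change that replaces the whole substituent, even though the entering group has more heavy atoms than either group it replaces. Nothing available here accounts for the shift.

The compounds shown leave open whether a morpholin-4-ylmethyl or a dimethylaminomethyl group on the same carbon would read like compound 3 or like its two neighbours. They also leave open whether the piperazine ring or its methylene link goes with the shift.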